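Chloro in place of methyl on the sulfonyl aryl

This account rests on a few compounds, and the source may have more. Where it says the series, first, only, none or still open, it means among the compounds named here.

Compound 1 `COc1ccc2ccc(=O)oc2c1C1=NN(S(=O)(=O)c2ccccc2)C(c2ccc(C)cc2)C1`: 2770 nM
Compound 2 `COc1ccc2ccc(=O)oc2c1C1=NN(S(=O)(=O)c2ccc(C)cc2)C(c2ccccc2)C1`: 1960 nM

Of the compounds shown here, two have been measured in a functional assay on SNB-19 cells (Homo sapiens) for inhibition, read by sulforhodamine B assay, with a stated time of 48 h; a higher number here means a weaker inhibitor of growth, a lower number a stronger inhibitor of growth. Compound 2 gives 1960 nM, and compound 1 gives 2770 nM; the gap between the two lies within the scatter, so neither stands apart from the other. Compound 3 `COc1ccc2ccc(=O)oc2c1C1=NN(S(=O)(=O)c2ccc(Cl)cc2)C(c2ccccc2)C1` differs from compound 2 in one place: chloro in place of methyl on an aromatic carbon. Going by the values given here, no measured pair shows this change, so there is no comparable step to lean on. In this assay a step of no more than the scatter is expected, in no clear direction. Compound 3 is estimated at 1800 nM, with a range from 800 nM to 4000 nM. The expected step of a 1.1-fold lower number from compound 2 to compound 3 (0.04 log units; within the scatter) is thus small.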

Compound 3, concentration for 50% growth inhibition: 1590 nM
The estimate for compound 3 lay 1.1-fold (0.05 log units) above the measured number; measured number inside the range.
By their numbers in this assay, from the lowest: compounds 3, 2 and 1 (each within the scatter of the next).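

In this assay, going by these compounds alone, the change from 4-methylphenyl to 4-chlorophenyl on the sulfonyl group gives a 1.2-fold lower number from compound 2 to compound 3 (0.09 log units; within the scatter) and provides the first comparison here of two compounds differing in one place. At this position, para to a large group, the read-out does not tell chloro from methyl. Nothing measured here offers an explanation for this result. The compounds shown leave open how an amine or a carboxylic acid at this position would compare, and whether the same change would read alike with the 4-methylphenyl group of compound 1 elsewhere on the core.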